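Trimming the Side Group on a Urea Kinase Inhibitor

This account rests on a few compounds, and the source may have more. Where it says the series, first, only, none or still open, it means among the compounds named here.

Within the data shown here, compound 2 `CNc1cc(Oc2ccc(NC(=O)Nc3cccc(C(C)F)c3)cc2)ncn1` gives 79 nM in an assay on isolated protein for inhibition of serine/threonine-protein kinase TNNI3K (Homo sapiens) (on this read-out higher numbers stand for weaker inhibition and lower numbers for stronger inhibition), one of only two numbers known here. The other belongs to compound 1 `CNc1cc(Oc2ccc(NC(=O)Nc3cccc(C(C)(C)C)c3)cc2)ncn1`, which gives 40 nM in this assay; the step of a 2.0-fold higher number from compound 1 to compound 2 (0.30 log units; within the scatter) lies within the scatter. Compound 3 `CNc1cc(Oc2ccc(NC(=O)Nc3cccc(C)c3)cc2)ncn1` differs from compound 2 by methyl in place of 1-fluoroethyl on an aromatic carbon. Among the measured compounds shown here, that single earlier step, which also changed the group on this aromatic carbon, is the only guide, and it moved the number little. Compound 3 is therefore expected to show a 1.9-fold higher number from compound 2 to compound 3 (0.28 log units; within the scatter), a modest weakening with wide uncertainty. The estimate for compound 3 is 150 nM, expected to fall between 50 nM and 500 nM.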

Compound 3, half-maximal inhibitory concentration: 1260 nM
Compound 3: the middle estimate sits 8.4-fold (0.92 log units) below what was measured, outside the stated range (above it).
By their numbers in this assay, from the lowest: compounds 1 and 2 (each within the scatter of the next); then compound 3.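

Methyl in place of 1-fluoroethyl proves to be a large step (a 16-fold higher number from compound 2 to compound 3 (1.20 log units; beyond the scatter)), and methyl in place of tert-butyl is large too (a 32-fold higher number from compound 1 to compound 3 (1.50 log units; beyond the scatter)). So the number at this aromatic carbon can move far, even though tert-butyl and 1-fluoroethyl stay within the scatter of each other. No measurement available here explains why methyl behaves so differently.

Open, from the compounds shown here alone, is whether ethyl or isopropyl on this carbon would read like compound 2 or like compound 3. Also open, going by these compounds, is how an amine or a carboxylic acid would read here.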